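Cytotoxicity notes on the shared core: step to compound 4

This account rests on a few compounds, and the source may have more. Where it says the series, first, only, none or still open, it means among the compounds named here.

Compound 3 `COc1ccccc1C(=O)c1ccn(-c2ccc3c(c2)B(O)OC3)c1` is one of three measured members of the series. In an ADME assay on L929 cells (Mus musculus) for cytotoxicity, read by resazurin assay, with a stated time of 72 h (a lower number here means a stronger inhibitor, a higher number a weaker inhibitor), compound 3 gives > 10 ug/mL, which is a limit of the assay and not a number. Compound 1 `O=C(c1ccc(Cl)cc1)c1ccn(-c2ccc3c(c2)B(O)OC3)c1` gives > 10 ug/mL in this assay, likewise a limit. Compound 2 `Cc1ccccc1C(=O)c1ccn(-c2ccc3c(c2)B(O)OC3)c1` gives > 10 ug/mL in this assay, again a limit. All three values thus sit at the same limit (the limit of > 10 ug/mL in this assay, at which 3 of the 3 values shown sit), so the steps a step that the two limits leave unreadable from compound 1 to compound 2, a step that the two limits leave unreadable from compound 1 to compound 3 and a step that the two limits leave unreadable from compound 2 to compound 3 cannot be read; none of them shows whether exchanging the aryl on the carbonyl carbon moves cytotoxicity at all.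

Compound 4 `NCc1ccc(C(=O)c2ccn(-c3ccc4c(c3)B(O)OC4)c2)cc1` is not yet measured in this assay. It differs from compound 3 by 4-(aminomethyl)phenyl in place of 2-methoxyphenyl on a carbonyl carbon. The measured steps that bear on this change are those that swap the aryl on the carbonyl carbon, a step that the two limits leave unreadable from compound 1 to compound 3 and a step that the two limits leave unreadable from compound 1 to compound 2, and both are unreadable; the shared core is unchanged in every member. Within the data shown here, no measured step therefore points to a change in either direction, and the expected step in this assay is a step that the limit leaves unreadable from compound 3 to compound 4. Compound 4 is expected to give 15 ug/mL in this assay, within 5 ug/mL to 50 ug/mL, and most likely to be reported again only as a limit.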

Compound 4, half-maximal inhibitory concentration: > 10 ug/mL
Compound 4: no number, only a limit; the forecaster's own chance of this, stated with the estimate: 80%; the middle value is on the limit's open side.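

Among these compounds, no step among compounds 1, 2, 3 and 4 can be read, because compound 4 joins the other three at a limit of the assay, which is not a number: the limit of > 10 ug/mL in this assay, at which 4 of the 4 values shown sit.

The compounds shown leave open whether exchanging the aryl on the carbonyl carbon changes the read-out of this assay at all, and where the half-maximal concentration of any of the four lies.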